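Side-chain extension on compound 3: expectation for compound 4

The source may report more compounds than this note shows. Statements on the series, on what has been measured and on what is new or still open speak of the compounds shown alone.

Compound 1 `CCCCCCCCN(C)C(=O)Cn1cc(Cc2cnc(O)nc2)c(=O)nc1SCc1ccc(F)cc1`: 66%
Compound 2 `CCCCCCCCN(C)C(=O)Cn1cc(Cc2cnc(=O)n(CC)c2)c(=O)nc1SCc1ccc(F)cc1`: 48%
Compound 3 `CCCCCCCCCCCCN(C)C(=O)Cn1cc(Cc2cnc(=O)n(C)c2)c(=O)nc1SCc1ccc(F)cc1`: 75%

In a functional assay on a cell-free system (plasma) for inhibition of platelet-activating factor acetylhydrolase (Homo sapiens), tested at 100 nM (on this read-out higher numbers stand for more inhibition at the one concentration tested (going by the name of the read-out) and lower numbers for less inhibition), compound 3 stands highest of the three numbers; compound 1 lies nearest, within the scatter, and compound 2 lies furthest, beyond it. Compound 4 `CCCCCCCCCCCCN(C)C(=O)Cn1cc(Cc2cnc(=O)n(CCO)c2)c(=O)nc1SCc1ccc(F)cc1` differs from compound 3 by hydroxymethyl in place of hydrogen on a saturated chain carbon bound to an aromatic nitrogen. For the measured compounds named here, no measured step alters the group on that aromatic nitrogen; the only step on the same side ring, a number 18 percentage points lower from compound 1 to compound 2 (beyond the scatter), changes a different place and is modest. Compound 2 and compound 3 differ in two places, so their gap cannot be assigned. The change is therefore expected to give at most a small step, a number 9 percentage points lower from compound 3 to compound 4 (within the scatter), in this assay. Compound 4 is estimated at 66%, in the range 46% to 84%.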

Compound 4, a percentage reported as inhibition, at one concentration (the size of the read-out at that concentration, not a potency): 77%
Beside the measured number, compound 4's estimate is 11 percentage points below it, and the stated range covers the measured number.
By their numbers in this assay, from the lowest: compound 2; then compounds 1, 3 and 4 (each within the scatter of the next, the first and the last beyond it).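

Hydroxymethyl in place of hydrogen on a saturated chain carbon bound to an aromatic nitrogen, which reads as methyl to 2-hydroxyethyl, is the first change measured at this place, and in this assay it stays within the scatter (a number 2 percentage points higher from compound 3 to compound 4 (within the scatter)). This place therefore accepts a hydrogen-bond donor and acceptor on the chain in compound 4 with no step beyond the scatter. Nothing available explains this result.

From the compounds shown here alone, whether an amine, a carboxylic acid or a longer chain carrying a hydroxyl would be accepted at this place stays open. Also open, going by these compounds, is whether the same change would give a similar step on the amide chain of compound 2.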